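Iodo in Place of Tert-butyl: Tolerance Expected to Hold

A few compounds are considered here, and "the series" means these few. Any claim that something is new, unique, unknown or untested is made for them only; others in the source may bear on it.

Within the data shown here, the three compounds measured so far share a core in which an aryl ketone is joined through a double bond to a second aromatic ring. Compound 1 `CC(C)(C)c1ccc(C(=O)/C=C/c2ccc([N+](=O)[O-])o2)cc1` carries a tert-butyl group and a nitro-substituted furan; compound 2 `O=C(/C=C/c1ccc([N+](=O)[O-])cc1)c1ccc(N2CCCCC2)cc1` carries a piperidine ring and a nitro-substituted benzene; compound 3 `O=C(/C=C/c1ccco1)c1ccc(N2CCCCC2)cc1` carries a piperidine ring and a plain furan.

All three were tested in an ADME assay on THP-1 cells (Homo sapiens) for cytotoxicity, read by resazurin assay, with a stated time of 72 h; a higher number here means that more compound is tolerated, a lower number that less compound is tolerated. Compound 1 gives only a limit of the assay, > 50000 nM. Compound 2 also gives only a limit, > 50000 nM. Compound 3 likewise gives only a limit, > 50000 nM. Compound 1 therefore stands where every other value stands, (the limit of > 50000 nM in this assay, at which 3 of the 3 values shown sit), and no difference among the three can be read from these numbers.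

Compound 4 `O=C(/C=C/c1ccc([N+](=O)[O-])o1)c1ccc(I)cc1` is compound 1 with one change: iodo in place of tert-butyl on an aromatic carbon. Among the measured compounds shown here, with every measured value sitting at the limit, there is no measured step on which to base a direction, so no change beyond the usual scatter is expected, and the step from compound 1 to compound 4 is estimated as a number no higher from compound 1 to compound 4 (the limit leaves the size open) in this assay. Compound 4 is accordingly expected to give about 50000 nM, within a range of 15000 nM to 150000 nM, most likely again reported only as a limit.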

Compound 4, half-maximal cytotoxic concentration: 49500 nM
For compound 4 the middle estimate is 1.0-fold (0.00 log units) above the measured one, within the range that was stated.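

In this assay, among these compounds, compound 4 gives 49500 nM, the first true number in this set and one that sits right at the edge of what the assay can report. Compound 1 gives > 50000 nM, which is a limit of the assay and not a number. Iodo in place of tert-butyl on this aromatic carbon therefore gives a number no higher from compound 1 to compound 4 (the limit leaves the size open), so the result shows that this place can carry iodo and keep cells tolerating the compound up to about the top of the tested range, while how much the change itself matters cannot be read.

From the compounds shown here alone, whether an amine or a carboxylic acid on the same aromatic carbon would be tolerated just as well remains open, and so does the part played by the nitro-substituted furan that compound 1 and compound 4 share. Any comparison across this set also stays restricted, since nearly everything still rests on a single ceiling rather than on numbers that can be set against one another: the limit of > 50000 nM in this assay, at which 3 of the 4 values shown sit.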